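Working notes: from compound 3 to compound 4 in the series

A few compounds are considered here, and "the series" means these few. Any claim that something is new, unique, unknown or untested is made for them only; others in the source may bear on it.

Measured so far in an assay on isolated protein for inhibition of leukotriene B4 receptor 1 (Homo sapiens), tested at 10 uM; on this read-out lower numbers stand for less inhibition and higher numbers for more inhibition at the one concentration tested (going by the name of the read-out):
compound 1 `CC(=O)c1ccc(OCCCCC#N)cc1O` gives 0%
compound 2 `CC(=O)c1cc(C)c(OCCCCC#N)cc1O` gives 79%
compound 3 `CCCCCc1cc(C(C)=O)c(O)cc1OCCCCC#N` gives 31%

Compound 3 stands second of the three numbers: a number 31 percentage points higher from compound 1 to compound 3 (beyond the scatter) places it beyond the scatter over compound 1, while a number 48 percentage points lower from compound 2 to compound 3 (beyond the scatter) places it well under compound 2. The steps already seen are large: a number 79 percentage points higher from compound 1 to compound 2 (beyond the scatter) and a number 31 percentage points higher from compound 1 to compound 3 (beyond the scatter) both raise the read-out, and the chain extension in a number 48 percentage points lower from compound 2 to compound 3 (beyond the scatter) pulls it back down.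

Compound 4 `CC(=O)c1cc(CC(C)O)c(OCCCCC#N)cc1O` has not yet been measured. It differs from compound 3 by 1-hydroxyethyl in place of butyl on a saturated chain carbon bound to an aromatic carbon. The step that bears most directly on this change is the one that lengthened methyl to pentyl, a number 48 percentage points lower from compound 2 to compound 3 (beyond the scatter), which cost a large amount; compound 4 undoes much of that lengthening, leaving a shorter branch than pentyl, though not the methyl of compound 2. The expectation is therefore a rise, beyond the scatter, back toward compound 2 but not fully to it: for compound 4 the estimated step is a number 24 percentage points higher from compound 3 to compound 4 (beyond the scatter). On that reasoning compound 4 is expected to give about 55%, in a range from 25% to 85%, with no limit expected in this assay.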

Compound 4, a percentage reported as inhibition, at one concentration (the size of the read-out at that concentration, not a potency): 10%
For compound 4 the middle estimate is 45 percentage points above the measured one, and the stated range ends above it.
By their numbers in this assay, from the lowest: compounds 1 and 4 (each within the scatter of the next); then compound 3; then compound 2.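

In this assay the 2-hydroxypropyl group on this aromatic carbon gives up nearly all of what methyl gives there (a number 69 percentage points lower from compound 2 to compound 4 (beyond the scatter)), and against hydrogen at the same place the change cannot be told from scatter (a number 10 percentage points higher from compound 1 to compound 4 (within the scatter)). Replacing pentyl with the shorter 2-hydroxypropyl does not recover the read-out but lowers it further (a number 21 percentage points lower from compound 3 to compound 4 (beyond the scatter)), so among compound 2, compound 3 and compound 4 the number does not follow chain length: methyl stands highest, pentyl second and 2-hydroxypropyl lowest. This position therefore responds to more than the length of the substituent, although no measurement at hand gives a reason for the fall.

Still open, going by these compounds, is whether the fall belongs to the hydroxyl or to the three-carbon chain that carries it, a question a plain propyl or ethyl group at this place would settle. Also open, on these data alone, is how far the read-out depends on what ends that chain, for instance a methoxy group, an amine or a carboxylic acid in place of the hydroxyl.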